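Ethyl esters of two acid scaffolds in a cytotoxicity screen

The source may report more compounds than this note shows. Statements on the series, on what has been measured and on what is new or still open speak of the compounds shown alone.

Compound 1 `CC(C)N(Cc1cccc(OCCCCCC(=O)O)c1)C(=O)c1ccc(-c2cccc(-c3ccccc3)c2)cc1` was tested in an ADME assay on HEK293 cells (Homo sapiens) for cytotoxicity, read by CellTiter-Glo and resazurin assay, with a stated time of 72 h; a lower number here means that less compound is needed, a higher number that more compound is needed for the effect. In this assay compound 1 gives > 26000 nM, which is a limit of the assay rather than a number. Compound 3 `CCOC(=O)CCCCCOc1cccc(CN(C(=O)c2ccc(-c3cccc(-c4ccccc4)c3)cc2)C(C)C)c1` differs from compound 1 by ethyl in place of hydrogen on an oxygen next to a carbonyl group. In this assay compound 3 gives > 26000 nM, again only a limit. Hence a step that the two limits leave unreadable from compound 1 to compound 3, since (the limit of > 26000 nM in this assay, at which 3 of the 3 values shown sit).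

Compound 2 `CC(C)N(Cc1cccc(OCCCCCC(=O)O)c1)C(=O)c1ccc(-c2cc3ccccc3n2S(=O)(=O)c2ccccc2)cc1` carries a different core; the difference between the cores of compound 1 and compound 2 is not broken down here. In this assay compound 2 gives > 26000 nM, likewise a limit. Compound 4 `CCOC(=O)CCCCCOc1cccc(CN(C(=O)c2ccc(-c3cc4ccccc4n3S(=O)(=O)c3ccccc3)cc2)C(C)C)c1` arises from compound 2 by the same change, (ethyl in place of hydrogen on an oxygen next to a carbonyl group). With compound 1 and compound 3 both sitting at the limit of > 26000 nM in this assay, at which 3 of the 3 values shown sit, the step is expected to be a step that the limit leaves unreadable from compound 2 to compound 4. Compound 4 is estimated at 50000 nM, between 20000 nM and 200000 nM, and is expected to be reported as a limit once more.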

Compound 4, half-maximal effective concentration: > 26000 nM
Compound 4 gave a limit, no number (the forecaster's own chance of this, stated with the estimate: 90%); the middle value does not contradict the limit.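

Compound 2 and compound 4 both stand only as limits, so no step can be read between them: the limit of > 26000 nM in this assay, at which 4 of the 4 values shown sit. The compounds shown leave open what actual number any of them would give in this assay, and whether ethyl in place of hydrogen changes it.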